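The source may report more compounds than this note shows. Statements on the series, on what has been measured and on what is new or still open speak of the compounds shown alone.

Measured compounds:
compound 1 `Cn1c(-c2ccc(NC(=O)CCl)cc2)nc(-c2ccccc2)c1-c1ccccc1` — 15.1%
compound 2 `Cn1c(-c2ccc(NC(=O)CSc3nc4ccccc4o3)cc2)nc(-c2ccccc2)c1-c1ccccc1` — 44.9%

Of the compounds shown here, two have been measured in a functional assay on HT-29 cells (Homo sapiens) for cytotoxicity, read by MTT assay, with a stated time of 24 h, tested at 6.4 ug/mL; a lower number here means a weaker effect, a higher number a stronger effect of the compound at the concentration tested. In this assay compound 1 gives 15.1%, and compound 2 gives 44.9%. Within the data shown here, the only measured step is a number 29.8 percentage points higher from compound 1 to compound 2 (beyond the scatter). Compound 2 therefore stands highest of the two numbers, with compound 1 as its nearest neighbour, beyond the scatter.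

The compound now to be judged is compound 3 `Cn1c(-c2ccc(NC(=O)CSc3nc4cc(Cl)ccc4o3)cc2)nc(-c2ccccc2)c1-c1ccccc1`. It differs from compound 2 by chloro in place of hydrogen on an aromatic carbon. Among the measured compounds shown here, this is a change on the bicyclic ring that entered in the step from compound 1 to compound 2, not a change of the kind already measured, so no measured step bears directly on it. The step from compound 1 to compound 2 only shows that the bicyclic group as a whole raises the value; it says nothing about a chloro on that group. With nothing to point in either direction, the expected step in this assay is small. The expected step is a number 1.1 percentage points higher from compound 2 to compound 3 (within the scatter), within the scatter. Compound 3 is estimated at 46%, with a range from 28% to 64%.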

Compound 3, a percentage reported as activity, at one concentration (the size of the read-out at that concentration, not a potency): 29.4%
Estimate against measurement, compound 3: 16.6 percentage points above; low and high end bracket the measured number.
By their numbers in this assay, from the lowest: compound 1; then compound 3; then compound 2.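

In this assay the carbon that carries the new chloro is not a neutral place: turning 1,3-benzoxazol-2-yl into 5-chloro-1,3-benzoxazol-2-yl gives a number 15.5 percentage points lower from compound 2 to compound 3 (beyond the scatter) and so takes back part of what the bicyclic group had added. Part of that gain survives, however, since replacing the chloro on the chain with (5-chloro-1,3-benzoxazol-2-yl)sulfanyl still gives a number 14.3 percentage points higher from compound 1 to compound 3 (beyond the scatter) in this comparison, so the substituted bicyclic group keeps an advantage over the simple chloroacetamide end of compound 1. Nothing available explains why a single added chlorine atom on this ring lowers the number.

The compounds shown leave open whether the fall belongs to chloro alone, or whether a fluoro, a methyl or a methoxy on the same carbon would lower the number as well. They also leave open how a chloro would read on another carbon of that six-membered ring and, as each number comes from a single tested concentration, how the effects of these compounds would compare at other concentrations.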